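The compounds below may be only part of what the source reports. "The series", "measured", "known", "first", "only" and "open" are said of these compounds alone.

In a functional assay on MGC-803 cells (Homo sapiens) for inhibition, read by sulforhodamine B assay (on this read-out higher numbers stand for weaker inhibition and lower numbers for stronger inhibition), three compounds on a shared core have been measured, and they differ in the group on an amine nitrogen. Compound 1 `O=C1C=C(NC2CCCCC2)C(=O)c2c1nc1n2[C@H]2OC[C@@H](O)[C@H]2OC1`, with cyclohexyl, reads > 8000 nM, which is a limit of the assay and not a number. Compound 2 `CCc1ccc(NC2=CC(=O)c3nc4n(c3C2=O)[C@H]2OC[C@@H](O)[C@H]2OC4)cc1`, with 4-ethylphenyl, gives 1290 nM. Compound 3 `Cc1ccc(NC2=CC(=O)c3nc4n(c3C2=O)[C@H]2OC[C@@H](O)[C@H]2OC4)cc1C`, with 3,4-dimethylphenyl, gives 860 nM. These last two cannot be told apart, since the gap is a 1.5-fold lower number from compound 2 to compound 3 (0.18 log units; within the scatter), so compound 3 shares the better end of the numbers with compound 2.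

Compound 4 `O=C1C=C(N2CCCC2)C(=O)c2c1nc1n2[C@H]2OC[C@@H](O)[C@H]2OC1` has pyrrolidin-1-yl in place of (3,4-dimethylphenyl)amino on a double-bonded ring carbon. Among the compounds with values here, no measured step makes this exact swap. The closest guides are the two steps that replace cyclohexyl with an aromatic ring: an at least 6.2-fold lower number from compound 1 to compound 2 (0.79 log units; beyond the scatter) and an at least 9.3-fold lower number from compound 1 to compound 3 (0.96 log units; beyond the scatter). Read in reverse, they suggest that giving up the aromatic ring for a non-aromatic one raises the number, meaning weaker inhibition. Pyrrolidin-1-yl is not cyclohexyl on an amine nitrogen, however, so this guide is only approximate. A clear rise is expected, and a reading at the limit is quite possible. The expected change is a 5.8-fold higher number from compound 3 to compound 4 (0.76 log units; beyond the scatter). For compound 4 the estimate is 5000 nM, with an expected range of 1800 nM to 14000 nM.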

Compound 4, half-maximal inhibitory concentration: > 16000 nM
Compound 4: only a limit was reported (the forecaster's own chance of this, stated with the estimate: 45%); at least 3.2-fold (0.50 log units) between middle value and limit.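

In this assay, replacing (3,4-dimethylphenyl)amino with pyrrolidin-1-yl on the double-bonded ring carbon gives an at least 18-fold higher number from compound 3 to compound 4 (1.26 log units; beyond the scatter), and replacing (4-ethylphenyl)amino in the same way gives an at least 12-fold higher number from compound 2 to compound 4 (1.09 log units; beyond the scatter), so among these compounds the two with an aromatic ring on the amine nitrogen read clearly lower than compound 4, whose ring is non-aromatic and joined through its own nitrogen. Compound 4 is a limit of the assay and not a number: the limit of > 16000 nM in this assay, at which 1 of the 4 values shown sits.
Compound 1, which also carries a non-aromatic ring but keeps the hydrogen-bond donor on its amine nitrogen, is a limit too, so in both compounds with a non-aromatic ring, with or without that donor, only a limit is available.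

Both ends of the step from compound 1 to compound 4 are limits, so that step cannot be read, and the two non-aromatic groups cannot be ranked. The change to compound 4 also removes the aromatic ring and the donor together, and a phenylamino group with a methyl group on its nitrogen could help tell apart what each of the two contributes.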